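Thioether Variation on a Shared Core: a Methoxybenzyl Analogue

The source may report more compounds than this note shows. Statements on the series, on what has been measured and on what is new or still open speak of the compounds shown alone.

Measured so far:
compound 1 `Cc1cc(N2CC[C@@H](C)[C@@H](N(C)c3ncnc4[nH]ccc34)C2)n2nc(SCC3CC3)nc2n1` — 21400 nM
compound 2 `Cc1cc(N2CC[C@@H](C)[C@@H](N(C)c3ncnc4[nH]ccc34)C2)n2nc(SCCCc3ccccc3)nc2n1` — > 100000 nM
compound 3 `C#CSc1nc2nc(C)cc(N3CC[C@@H](C)[C@@H](N(C)c4ncnc5[nH]ccc45)C3)n2n1` — 35100 nM

All three compounds share one core and differ only in the group carried on the sulfur. In a functional assay on HGC-27 cells (Homo sapiens) for inhibition, read by MTT assay, with a stated time of 72 h (on this read-out lower numbers stand for stronger inhibition and higher numbers for weaker inhibition), compound 1 gives 21400 nM, the lower of the two plain numbers shown. Compound 3 gives 35100 nM; the step of a 1.6-fold higher number from compound 1 to compound 3 (0.21 log units; within the scatter) keeps the two within the scatter, so no order between them can be claimed. For compound 2 the assay reports only a limit rather than a number, (the limit of > 100000 nM in this assay, at which 1 of the 3 values shown sits). That limit makes the step of an at least 4.6-fold higher number from compound 1 to compound 2 (0.66 log units; beyond the scatter) at least modest, and an at least 2.8-fold lower number from compound 2 to compound 3 (0.45 log units; beyond the scatter) points the same way.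

Compound 4 `COc1ccc(CSc2nc3nc(C)cc(N4CC[C@@H](C)[C@@H](N(C)c5ncnc6[nH]ccc56)C4)n3n2)cc1` has not yet been measured. It differs from compound 1 in one place: 4-methoxyphenyl in place of cyclopropyl on a saturated chain carbon bound to a sulfur. The step that bears on it most directly is an at least 4.6-fold higher number from compound 1 to compound 2 (0.66 log units; beyond the scatter), where a phenethyl group, also holding an aromatic ring, took the place of cyclopropyl on the saturated chain carbon bound to the sulfur, and the number went up. An upward step beyond the scatter is therefore expected for compound 4, a 2.8-fold higher number from compound 1 to compound 4 (0.45 log units; beyond the scatter). Compound 4 is estimated at 60000 nM, within a range from 25000 nM to 150000 nM.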

Compound 4, half-maximal inhibitory concentration: 18200 nM
Compound 4: the middle estimate sits 3.3-fold (0.52 log units) above what was measured; the measured number lies below the stated range.
By their numbers in this assay, from the lowest: compounds 4, 1 and 3 (each within the scatter of the next). At a limit, above all of these: compound 2.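

Both a 1.2-fold lower number from compound 1 to compound 4 (0.07 log units; within the scatter) and a 1.9-fold lower number from compound 3 to compound 4 (0.29 log units; within the scatter) lie within the scatter, so in this assay the 4-methoxybenzyl group on the sulfur cannot be told apart from the much smaller cyclopropylmethyl or ethynyl groups. An aromatic ring at this position therefore does not by itself push the number up. The step of an at least 5.4-fold lower number from compound 2 to compound 4 (0.73 log units; beyond the scatter) is only a bound and lies beyond the scatter, which separates two ring-bearing groups, and compound 2 is reported only as a limit: the limit of > 100000 nM in this assay, at which 1 of the 4 values shown sits.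

Compound 2 and compound 4 differ both in the chain leading to the ring and in the methoxy group, so these compounds cannot show which of the two matters. A plain benzyl group or a 4-methoxyphenylpropyl group on the sulfur would pull those two differences apart.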